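The source may hold more compounds than are shown below. What is called first, only, known or untested is meant among the compounds shown, and "the series" means these compounds.

Of the compounds shown here, two sharing one core have been measured in an ADME assay on Vero cells (Chlorocebus sabaeus) for cytotoxicity, read by neutral red uptake, tested at 394 ug/mL; a higher number here means a weaker effect of the compound at the concentration tested, a lower number a stronger effect. Compound 1 `COc1ccc(C2SCC(=O)N2CCN2CCCCC2)cc1` gives 73% in this assay. Compound 2 `O=C1CSC(c2ccc([N+](=O)[O-])cc2)N1CCN1CCCCC1` gives 66% in this assay. Going by the values given here, the only step between measured compounds, a number 7 percentage points lower from compound 1 to compound 2 (within the scatter), puts a nitro group in place of a methoxy group on an aromatic carbon and stays within the scatter. Of the two numbers shown, the one for compound 2 is the lower on paper, with compound 1 its nearest neighbour, but the gap lies within the scatter, so the two cannot be told apart.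

Among the compounds with values here, compound 3 `O=C1CSC(c2ccc(F)cc2)N1CCN1CCCCC1` has not yet been measured. fluoro in place of nitro on an aromatic carbon Like the one measured step, this change sits on an aromatic carbon. Within the data shown here, that step, a number 7 percentage points lower from compound 1 to compound 2 (within the scatter), was within the scatter and is the only guide available; no measured step shows what a fluoro group does at this place. The step of a number 4 percentage points higher from compound 2 to compound 3 (within the scatter) is therefore expected to stay within the scatter, in no particular direction. Compound 3 is estimated to give 70% in this assay, with a range from 52% to 88%.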

Compound 3, a percentage reported as activity, at one concentration (the size of the read-out at that concentration, not a potency): 52%
The estimate for compound 3 lay 18 percentage points above the measured number, within the range that was stated.
By their numbers in this assay, from the lowest: compound 3; then compounds 2 and 1 (each within the scatter of the next).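

Changing the group on the aromatic carbon, para to a large group, can move the read-out in this assay by more than the usual scatter: putting fluoro in place of nitro gives a number 14 percentage points lower from compound 2 to compound 3 (beyond the scatter) and putting fluoro in place of methoxy gives a number 21 percentage points lower from compound 1 to compound 3 (beyond the scatter) in the same measure. The earlier swap of nitro for methoxy could not be told apart from repeat noise, so this position had shown no measurable sensitivity until now; with fluoro it has, and the lower number means a stronger effect on the cells at the one concentration tested, although both steps are only modest in size. Nothing measured here accounts for why fluoro separates from the other two groups.

Going by these compounds, whether a chloro group, a plain hydrogen, an amine or a carboxylic acid on the same aromatic carbon would read like fluoro, or like nitro and methoxy, remains open. On these data alone, all three compounds also share one core and one tested concentration, so it is unknown whether the fluoro step would hold on another core, and these numbers do not give a potency.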